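A Methoxy Group on the Dihydroindole of Compound 3

This account rests on a few compounds, and the source may have more. Where it says the series, first, only, none or still open, it means among the compounds named here.

In a functional assay on KYSE-450 cells (Homo sapiens) for inhibition, read by CCK-8 assay, with a stated time of 48 h (a lower number here means a stronger inhibitor, a higher number a weaker inhibitor), compound 1 `COc1ccc(CN(C(=O)CSC(=S)N2CCN(C(C)=O)CC2)c2cc(OC)c(OC)c(OC)c2)cc1` gives 370 nM, compound 2 `COc1ccc(CN(C(=O)CSC(=S)N2CCCC2)c2cc(OC)c(OC)c(OC)c2)cc1` gives 13800 nM and compound 3 `COc1ccc(CN(C(=O)CSC(=S)N2CCc3ccccc32)c2cc(OC)c(OC)c(OC)c2)cc1` gives 6940 nM. Compound 3 therefore stands level with compound 2 and well away from compound 1. Compound 4 `COc1ccc(CN(C(=O)CSC(=S)N2CCc3cc(OC)ccc32)c2cc(OC)c(OC)c(OC)c2)cc1` keeps everything in compound 3 except for methoxy in place of hydrogen on an aromatic carbon, which turns 2,3-dihydro-1H-indol-1-yl into 5-methoxy-2,3-dihydro-1H-indol-1-yl: methoxy in place of hydrogen on an aromatic carbon.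

The measured steps all concern the group on the thiocarbonyl carbon. Pyrrolidin-1-yl in place of 4-acetylpiperazin-1-yl is a 37-fold higher number from compound 1 to compound 2 (1.57 log units; beyond the scatter), and 2,3-dihydro-1H-indol-1-yl in place of 4-acetylpiperazin-1-yl is a 19-fold higher number from compound 1 to compound 3 (1.27 log units; beyond the scatter). Both are large, but each exchanges the whole group. The closer comparison, 2,3-dihydro-1H-indol-1-yl in place of pyrrolidin-1-yl, is a 2.0-fold lower number from compound 2 to compound 3 (0.30 log units; within the scatter). Among the measured compounds shown here, no measured step adds a substituent to the aromatic ring itself, so the direction remains open. With the small size of a 2.0-fold lower number from compound 2 to compound 3 (0.30 log units; within the scatter) as the guide, the expected change is a 1.2-fold lower number from compound 3 to compound 4 (0.06 log units; within the scatter), which would not clearly exceed the scatter. For compound 4, the estimated value in this assay is 6000 nM, with an expected range of 2000 nM to 16000 nM.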

Compound 4, half-maximal inhibitory concentration: 10200 nM
For compound 4 the middle estimate is 1.7-fold (0.23 log units) below the measured one; low and high end bracket the measured number.
By their numbers in this assay, from the lowest: compound 1; then compounds 3, 4 and 2 (each within the scatter of the next).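

In this assay, among the compounds shown here, methoxy in place of hydrogen on this aromatic carbon, meta to a fused ring and para to a fused ring, produces no step that can be told from the scatter (a 1.5-fold higher number from compound 3 to compound 4 (0.17 log units; within the scatter)). This is the only step shown that adds a substituent to this ring, and it leaves the 5-methoxy-2,3-dihydro-1H-indol-1-yl compound level with the pyrrolidin-1-yl compound (a 1.4-fold lower number from compound 2 to compound 4 (0.13 log units; within the scatter)) and still far from the 4-acetylpiperazin-1-yl compound (a 28-fold higher number from compound 1 to compound 4 (1.44 log units; beyond the scatter)). The large gap to compound 1 thus remains with methoxy in place, and no measurement is at hand that bears on this result.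

The compounds shown leave open whether another group on this same carbon, such as fluorine, a hydroxyl, an amine or a carboxylic acid, would give a step beyond the scatter. They also leave open whether methoxy on another carbon of this ring would behave as it does here, and whether an acetyl group attached to the 2,3-dihydro-1H-indol-1-yl ring would give any of the gap back.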